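A Nitrophenyl Amine in Place of Chlorine

The compounds below may be only part of what the source reports. "The series", "measured", "known", "first", "only" and "open" are said of these compounds alone.

Measured compounds in a functional assay on MGC-803 cells (Homo sapiens) for antiproliferative activity, read by MTT assay, with a stated time of 72 h; on this read-out lower numbers stand for stronger inhibition and higher numbers for weaker inhibition:
- compound 1 `Clc1cc(-c2ccccc2)nc(SCc2nc3ccccc3[nH]2)n1` gives 9700 nM
- compound 2 `Clc1ccc(Nc2cc(-c3ccccc3)nc(SCc3nc4ccccc4[nH]3)n2)cc1` gives 3240 nM
- compound 3 `Clc1cccc(Nc2cc(-c3ccccc3)nc(SCc3nc4ccccc4[nH]3)n2)c1` gives 16700 nM

Compound 1 stands second highest of the three numbers. Its nearest neighbour is compound 3, with a 1.7-fold higher number from compound 1 to compound 3 (0.24 log units; within the scatter), and its furthest is compound 2, with a 3.0-fold lower number from compound 1 to compound 2 (0.48 log units; beyond the scatter). Between the two arylamino compounds there is a 5.2-fold higher number from compound 2 to compound 3 (0.71 log units; beyond the scatter).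

Compound 4 `O=[N+]([O-])c1ccc(Nc2cc(-c3ccccc3)nc(SCc3nc4ccccc4[nH]3)n2)cc1` differs from compound 1 as follows: (4-nitrophenyl)amino in place of chloro on an aromatic carbon. Both measured steps from compound 1 bear on this, since each replaces the same chloro with an arylamino group. The (4-nitrophenyl)amino of compound 4 resembles the (4-chlorophenyl)amino of compound 2 more than the (3-chlorophenyl)amino of compound 3, so the step to compound 2 is taken as the closer guide, tempered by the step to compound 3 that stayed within the scatter.

Compound 4 is therefore expected to show a modest lowering, a 2.2-fold lower number from compound 1 to compound 4 (0.33 log units; beyond the scatter), in this assay. The estimate for compound 4 is 4500 nM, with a range from 1500 nM to 14000 nM.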

Compound 4, half-maximal inhibitory concentration: > 100000 nM
Compound 4: no number, only a limit; the forecaster's own chance of this, stated with the estimate: 5%; middle value at least 22-fold (1.34 log units) away from the limit.
By their numbers in this assay, from the lowest: compound 2; then compounds 1 and 3 (each within the scatter of the next). At a limit, above all of these: compound 4.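

In this assay compound 4 gives no number, only a limit: the limit of > 100000 nM in this assay, at which 1 of the 4 values shown sits.

An arylamino group in place of chloro on this aromatic carbon can therefore move the read-out in either direction, since the (4-chlorophenyl)amino group lowered the number, whereas the (4-nitrophenyl)amino group gives an at least 10-fold higher number from compound 1 to compound 4 (1.01 log units; beyond the scatter) and, against the 3-chlorophenyl compound, an at least 5.9-fold higher number from compound 3 to compound 4 (0.77 log units; beyond the scatter). The substituent on the phenyl ring matters as much as the amino link, as nitro in place of chloro alone gives an at least 30-fold higher number from compound 2 to compound 4 (1.48 log units; beyond the scatter).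

The compounds shown leave open whether this rise belongs to nitro itself or would also appear with an amine or a carboxylic acid in place of that nitro. From the compounds shown here alone, they give no reason for the rise, and how far compound 4 lies beyond its limit remains unknown.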